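This account rests on a few compounds, and the source may have more. Where it says the series, first, only, none or still open, it means among the compounds named here.

Going by the values given here, compound 2, `O=C(C1CCCN(Cc2ccc(F)cc2)C1)N1CCN(c2ccccc2Cl)CC1`, gives 67% in a functional assay on a cell-free system (Platelet, plasma, Homo sapiens), with stated times of 4 min and 5.5 min, tested at 0.5 uM (on this read-out lower numbers stand for a stronger effect and higher numbers for a weaker effect at the one concentration tested), and compound 1, `O=C(C1CCCN(Cc2ccccc2F)C1)N1CCN(c2ccccc2Cl)CC1`, gives 73% there; the one measured step, a number 6 percentage points lower from compound 1 to compound 2 (within the scatter), leaves the two within the scatter of each other. Compound 3, `O=C(c1ccc(Br)cc1)N1CCCC(C(=O)N2CCN(c3ccccc3Cl)CC2)C1`, carries (4-bromophenyl)carbonyl in place of 4-fluorobenzyl on an amine nitrogen in a ring. Among the compounds with values here, no measured step touches this part of the structure, since the only known step moves a fluorine on the same benzyl group; it therefore gives no guide to the change in compound 3. Without such a guide, compound 3 is expected to give 67%, between 45% and 88%, a step of no change at the digits printed from compound 2 to compound 3 (within the scatter), with wide uncertainty.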

Compound 3, a percentage reported as activity, at one concentration (the size of the read-out at that concentration, not a potency): 75%
The estimate for compound 3 lay 8 percentage points below the measured number, and the stated range covers the measured number.
By their numbers in this assay, from the lowest: compounds 2, 1 and 3 (each within the scatter of the next).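

On the amine nitrogen in the ring, this assay shows a number 8 percentage points higher from compound 2 to compound 3 (within the scatter) on going to (4-bromophenyl)carbonyl, and a number 2 percentage points higher from compound 1 to compound 3 (within the scatter). So the earlier fluorine shift on the benzyl group is joined by a larger change, a carbonyl-linked bromophenyl group, that also leaves the read-out within the scatter. No supporting evidence on the origin of this result is available. This step changes the carbonyl and the halogen together, and 4-bromobenzyl or (4-fluorophenyl)carbonyl would separate them. From the compounds shown here alone, whether a group without an aromatic ring, such as acetyl, would fit this pattern remains open.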